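This account rests on a few compounds, and the source may have more. Where it says the series, first, only, none or still open, it means among the compounds named here.

Compound 1 `CS(=O)(=O)Nc1ccc2c(c1)S(=O)(=O)N=C(C1=C(O)C3CCCC3N(CCC3CC3)C1=O)N2` gives > 33000 nM in an ADME assay on Huh-7 cells (Homo sapiens) for cytotoxicity, with a stated time of 72 h; a higher number here means that more compound is tolerated, a lower number that less compound is tolerated.
Compound 2 `CS(=O)(=O)Nc1ccc2c(c1)S(=O)(=O)N=C(C1=C(O)C3CCCCCCC3N(Cc3ccc(F)cc3)C1=O)N2` gives > 33000 nM.
Compound 3 `CS(=O)(=O)Nc1ccc2c(c1)S(=O)(=O)N=C(C1=C(O)[C@H]3CCC[C@H]3N(Cc3ccc(F)c(F)c3)C1=O)N2` gives > 1000 nM.

All three measured compounds share the same core and were tested in this assay, and none of them returned a plain number. For compound 1 the value > 33000 nM is a limit of the assay, not a measured concentration. Compound 1 thus sits at the limit of > 33000 nM in this assay, at which 2 of the 3 values shown sit. Compound 3 sits at the other boundary, (the limit of > 1000 nM in this assay, at which 1 of the 3 values shown sits). Compound 4 `CS(=O)(=O)Nc1ccc2c(c1)S(=O)(=O)N=C(C1=C(O)C3CCCC3N(Cc3ccc(Cl)cc3)C1=O)N2` has not yet been measured. It differs from compound 1 in one place: 4-chlorophenyl in place of cyclopropylmethyl on a saturated chain carbon bound to an amide-type nitrogen in a ring. Going by the values given here, no pair of measured compounds differing in a single place is available, so the size of this kind of step is not known from the data here. Given that compound 1 shows only a limit in this assay, the step from compound 1 to compound 4 is expected to be none beyond the scatter, a step that the limit leaves unreadable from compound 1 to compound 4. Compound 4 is therefore expected to give about 40000 nM in this assay, within a range from 15000 nM to 100000 nM, and most likely to return only a limit again.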

Compound 4, half-maximal cytotoxic concentration: > 10000 nM
Compound 4 ended at the assay's limit; the forecaster's own chance of this, stated with the estimate: 80%; the middle value is on the limit's open side.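

Going by these compounds alone, compound 1 and compound 4 both return only limits in this assay, and no step between them can be read. Still open is the actual half-maximal cytotoxic concentration of each compound shown, and whether 4-chlorophenyl in place of cyclopropylmethyl changes it at all.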